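A few compounds are considered here, and "the series" means these few. Any claim that something is new, unique, unknown or untested is made for them only; others in the source may bear on it.

Compound 3, `COc1cc(F)ccc1N1C(=O)CSC1c1cccc(C(=O)NCCCCc2ccccc2)c1`, carries a 4-fluoro-2-methoxyphenyl on the amide-type nitrogen of its five-membered ring. In a functional assay on SJSA-1 cells (Homo sapiens) for inhibition, read by CCK-8 assay, with a stated time of 72 h, tested at 1 uM (a lower number here means less inhibition, a higher number more inhibition at the concentration tested (going by the name of the read-out)), compound 3 gives 77%, the second highest of the three numbers measured. Compound 1, `Cc1cccc(N2C(=O)CSC2c2cccc(C(=O)NCCCCc3ccccc3)c2)c1`, gives 84% in this assay, and the two lie within the scatter of each other, as a number 7 percentage points lower from compound 1 to compound 3 (within the scatter) shows. Compound 2, `CCN1C(=O)CSC1c1cccc(C(=O)NCCCCc2ccccc2)c1`, gives 3%, far below both, as a number 81 percentage points lower from compound 1 to compound 2 (beyond the scatter) and a number 74 percentage points higher from compound 2 to compound 3 (beyond the scatter) show.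

Compound 4, `CC(F)(F)c1cccc(N2C(=O)CSC2c2cccc(C(=O)NCCCCc3ccccc3)c2)c1`, differs from compound 3 in one place: a group of 10 heavy atoms (8 carbon, 2 fluorine; one six-membered aromatic ring of carbon only) in place of a group of 9 heavy atoms (7 carbon, 1 oxygen, 1 fluorine; one six-membered aromatic ring of carbon only), on an amide-type nitrogen in a ring. For the measured compounds named here, both steps that exchange one aromatic ring for an ethyl on that nitrogen were large, while the one step that exchanges one aromatic ring for another, from compound 1 to compound 3, stayed within the scatter. The change from compound 3 to compound 4 is again an aromatic ring in place of an aromatic ring, so in this assay compound 4 is expected to show a number 2 percentage points higher from compound 3 to compound 4 (within the scatter), a step within the scatter. The estimate for compound 4 is 79%, between 64% and 91%.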

Compound 4, a percentage reported as inhibition, at one concentration (the size of the read-out at that concentration, not a potency): 68%
Estimate against measurement, compound 4: 11 percentage points above, within the range that was stated.
By their numbers in this assay, from the lowest: compound 2; then compounds 4, 3 and 1 (each within the scatter of the next, the first and the last beyond it).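

The aromatic ring on the amide-type nitrogen again stands far above the ethyl, with a number 65 percentage points higher from compound 2 to compound 4 (beyond the scatter), so this gap now holds for three different aromatic groups at this position. For the compounds shown here, the substituent on that aromatic ring still counts to a degree: 1,1-difluoroethyl in place of methyl on an aromatic carbon gives a number 16 percentage points lower from compound 1 to compound 4 (beyond the scatter), the first step between two aromatic groups to pass the scatter, though only a modest one. Against the 4-fluoro-2-methoxyphenyl group the new group stays close, with a number 9 percentage points lower from compound 3 to compound 4 (within the scatter).

On these data alone, whether the aromatic ring itself or only the size of the group matters stays open, and a cyclohexyl or a benzyl on that nitrogen would separate the two. Also open, as far as these compounds go, is how an amine or a carboxylic acid in place of the 1,1-difluoroethyl on the aromatic carbon would read.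

Nothing available here explains these differences.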